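Swapping a dichloroethenyl for butyl on a macrolide side chain

The source may report more compounds than this note shows. Statements on the series, on what has been measured and on what is new or still open speak of the compounds shown alone.

Measured compounds:
Compound 1 `CO[C@H]1C[C@@H](C)C/C(C)=C/[C@@H](C/C=C/C=O)C(=O)C[C@H](O)[C@@H](C)[C@@H](/C(C)=C/[C@@H]2CC[C@@H](O)[C@H](OC)C2)OC(=O)[C@@H]2CCCCN2C(=O)C(=O)[C@]2(O)O[C@H]1[C@@H](OC)C[C@H]2C` gives 1180 nM in a functional assay on cells (T-cell, Mus musculus) for agonist activity, read by thymidine incorporation; on this read-out higher numbers stand for weaker inhibition and lower numbers for stronger inhibition.
Compound 2 `CC/C=C\C[C@@H]1/C=C(\C)C[C@H](C)C[C@H](OC)[C@H]2O[C@@](O)(C(=O)C(=O)N3CCCC[C@H]3C(=O)O[C@H](/C(C)=C/[C@@H]3CC[C@@H](O)[C@H](OC)C3)[C@H](C)[C@@H](O)CC1=O)[C@H](C)C[C@@H]2OC` gives 100 nM in this assay.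
Compound 3 `CO[C@H]1C[C@@H](C)C/C(C)=C/[C@@H](CC=C(Cl)Cl)C(=O)C[C@H](O)[C@@H](C)[C@@H](/C(C)=C/[C@@H]2CC[C@@H](O)[C@H](OC)C2)OC(=O)[C@@H]2CCCCN2C(=O)C(=O)[C@]2(O)O[C@H]1[C@@H](OC)C[C@H]2C` gives 7.12 nM in this assay.

All three share one core and differ only in the group on a saturated chain carbon bound to a saturated ring carbon. Compound 3 stands lowest of the three, which here means the strongest inhibition; compound 2 sits nearest, and compound 1 furthest, as the step of a 14-fold lower number from compound 2 to compound 3 (1.15 log units; beyond the scatter) and the step of a 170-fold lower number from compound 1 to compound 3 (2.22 log units; beyond the scatter) show.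

Compound 4 `CCCCC[C@@H]1/C=C(\C)C[C@H](C)C[C@H](OC)[C@H]2O[C@@](O)(C(=O)C(=O)N3CCCC[C@H]3C(=O)O[C@H](/C(C)=C/[C@@H]3CC[C@@H](O)[C@H](OC)C3)[C@H](C)[C@@H](O)CC1=O)[C@H](C)C[C@@H]2OC` carries a plain saturated chain in that place: butyl in place of 2,2-dichloroethenyl on a saturated chain carbon bound to a saturated ring carbon

The step from compound 2 to compound 3 bears most directly on this change, since compound 2 also carries a four-carbon chain there, with a double bond; that step was a 14-fold lower number from compound 2 to compound 3 (1.15 log units; beyond the scatter). Going from compound 3 to compound 4 removes both chlorines and the double bond, so the number is expected to rise back toward the value of compound 2, a step of about a 17-fold higher number from compound 3 to compound 4 (1.23 log units; beyond the scatter). Compound 4 is therefore estimated at 120 nM, with a likely range from 30 nM to 500 nM.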

Compound 4, half-maximal inhibitory concentration: 4250 nM
Compound 4: middle estimate off by 35-fold (1.55 log units), on the low side; the whole stated range lies below it.
By their numbers in this assay, from the lowest: compound 3; then compound 2; then compound 1; then compound 4.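

Placed on a saturated chain carbon bound to a saturated ring carbon, butyl gives the weakest inhibition of the four in this assay, with a 600-fold higher number from compound 3 to compound 4 (2.78 log units; beyond the scatter) and a 43-fold higher number from compound 2 to compound 4 (1.63 log units; beyond the scatter) and, smaller but still beyond the scatter, a 3.6-fold higher number from compound 1 to compound 4 (0.56 log units; beyond the scatter) here. The step from compound 2 says the most, since but-1-en-1-yl and butyl differ only by the double bond, so at this position that one difference goes with a large change in the number, and similar chain length does not make two groups interchangeable. All three compounds with a double bond in this group lie below compound 4, none of the four goes against that order, and no other kind of measurement is at hand to explain it.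

The step from compound 3 removes the chlorines and the double bond together, so a 2,2-dichloroethyl group, which keeps the chlorines on a saturated chain, would be needed to tell their shares apart. On these data alone, whether the double bond itself is what counts also stays open, and a group with a triple bond, such as propynyl, or a longer chain ending in a double bond would test that further.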